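The source may hold more compounds than are shown below. What is called first, only, known or untested is meant among the compounds shown, and "the series" means these compounds.

Compound 1 `CCOC(=O)CN(Cc1cc(F)cc(F)c1)c1ccc2c(c1)N(C)CC(C)(COc1ccc(C#N)cc1)O2`: > 100000 nM (a limit of the assay, not a number)
Compound 2 `CCOC(=O)CN(Cc1cccc(F)c1)c1ccc2c(c1)N(C)CC(C)(COc1ccc(C(=N)N)cc1)O2`: 6000 nM

The measurements so far come from a functional assay on HMEC-1 cells (Homo sapiens) for antiproliferative activity, read by cell counting, with a stated time of 7 days; on this read-out lower numbers stand for stronger inhibition and higher numbers for weaker inhibition. In this assay, going by the values given here, compound 2 gives 6000 nM, and this is the only actual number available. Compound 1 is reported as > 100000 nM, which is a limit of the assay.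

Compound 3 `CCOC(=O)CN(Cc1cc(F)cc(F)c1)c1ccc2c(c1)N(C)CC(C)(COc1ccc(C(=N)N)cc1)O2` is still to be measured. It has the structure of compound 2 with a single change: fluoro in place of hydrogen on an aromatic carbon. In words, fluoro takes the place of hydrogen on an aromatic carbon, so 3-fluorobenzyl becomes 3,5-difluorobenzyl.

Among the compounds with values here, no pair of measured compounds shows what this change does on its own, so there is no direct precedent for its effect. The expectation therefore starts from compound 2 at 6000 nM and, for so small a change, foresees no step beyond the usual scatter, in neither direction. The expected change is a 1.2-fold lower number from compound 2 to compound 3 (0.08 log units; within the scatter). For compound 3 the estimated value is 5000 nM, with an expected range from 1500 nM to 20000 nM.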

Compound 3, half-maximal inhibitory concentration: 6700 nM
The estimate for compound 3 lay 1.3-fold (0.13 log units) below the measured number; the range from low to high includes it.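

In this assay, fluoro in place of hydrogen on an aromatic carbon, which turns 3-fluorobenzyl into 3,5-difluorobenzyl, gives a 1.1-fold higher number from compound 2 to compound 3 (0.05 log units; within the scatter), so at this position the added fluoro leaves no effect that can be told from the scatter. Going by these compounds alone, with 3,5-difluorobenzyl held fixed, the nitrile and the amidine can now be compared on their own, and going from the nitrile to the amidine on the same aromatic carbon gives an at least 14-fold lower number from compound 1 to compound 3 (1.17 log units; beyond the scatter), the first large step in this set that can be tied to one place. Compound 1 is reported at a limit of the assay and not at a number, so this step gives only a minimum size: the limit of > 100000 nM in this assay, at which 1 of the 3 values shown sits.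

The compounds shown leave open whether a chloro or a methyl group at this same position of the benzyl ring would behave as fluoro does. They also leave open whether an aminomethyl group in place of the amidine, or a carboxylic acid in place of the ethyl ester, would keep the activity of compound 3.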